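The compounds below may be only part of what the source reports. "The series", "measured", "known", "first", "only" and "open" are said of these compounds alone.

Measured compounds:
- compound 1 `O=C1O[C@H]([C@@H](O)Cn2cc(CNS(=O)(=O)c3ccc(Cl)cc3F)nn2)C(OCc2ccccc2)=C1OCc1ccccc1`: 20700 nM
- compound 2 `O=C1O[C@H]([C@@H](O)Cn2cc(CNS(=O)(=O)c3ccc(F)cc3)nn2)C(OCc2ccccc2)=C1OCc1ccccc1`: 25000 nM
- compound 3 `CCCCCc1ccc(-c2cn(C/C=C3\OC(=O)C(OCc4ccccc4)=C3OCc3ccccc3)nn2)cc1`: > 100000 nM

Compounds 1 and 2 share a core and differ only on the sulfonyl sulfur. In a functional assay on HeLa cells (Homo sapiens) for antiproliferative activity, read by MTT assay, with a stated time of 72 h (a higher number here means a weaker inhibitor, a lower number a stronger inhibitor), compound 1 gives 20700 nM and compound 2 gives 25000 nM. The step of a 1.2-fold higher number from compound 1 to compound 2 (0.08 log units; within the scatter) is within the scatter, so the two are to be read as equal. Compound 2 therefore stands level with compound 1 among the two numbers available. For compound 3 this assay reports only a limit, > 100000 nM, and no number; compound 3 is one of the values that sit at the limit of > 100000 nM in this assay, at which 1 of the 3 values shown sits.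

Compound 4 `Cc1ccc(-c2cn(C[C@H](O)[C@H]3OC(=O)C(OCc4ccccc4)=C3OCc3ccccc3)nn2)cc1` is not yet measured. Its change from compound 2 is 4-methylphenyl in place of (((4-fluorophenyl)sulfonyl)amino)methyl on an aromatic carbon. For the measured compounds named here, no measured step bears on this change directly: the only step available, from compound 1 to compound 2, alters the aryl group on the sulfonyl sulfur and is within the scatter. Going by the values given here, compound 3 is the only compound carrying an aryl group directly on the five-membered ring, but it also differs from compound 2 in its core, so its limit can only hint. On that hint, a weaker inhibitor is expected for compound 4, with the step of a 2.4-fold higher number from compound 2 to compound 4 (0.38 log units; beyond the scatter) estimated in this assay. The estimate for compound 4 is 60000 nM, expected between 20000 nM and 150000 nM.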

Compound 4, half-maximal inhibitory concentration: 25500 nM
Beside the measured number, compound 4's estimate is 2.4-fold (0.37 log units) above it; measured number inside the range.
By their numbers in this assay, from the lowest: compounds 1, 2 and 4 (each within the scatter of the next). At a limit, above all of these: compound 3.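

Swapping the whole (((4-fluorophenyl)sulfonyl)amino)methyl group for 4-methylphenyl, on the aromatic carbon of the five-membered aromatic ring with 3 nitrogen, gives a 1.0-fold higher number from compound 2 to compound 4 (0.01 log units; within the scatter) in this assay, so compound 2 and compound 4 read as equal. The earlier step touched only the aryl group on the sulfonyl sulfur, whereas this one removes the sulfonyl and amino link altogether: the group that leaves has 12 heavy atoms, 1 hydrogen-bond donor and 2 hydrogen-bond acceptors, and the group that enters has 7 heavy atoms and neither donors nor acceptors. Within these compounds, then, the sulfonyl and amino link is not needed for activity at this level, and an aryl group set directly on the ring serves as well.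

As far as these compounds go, compound 3 differs from compound 4 in more than one place, so it cannot isolate the effect of this change, and its value is a limit: the limit of > 100000 nM in this assay, at which 1 of the 4 values shown sits. What stays open is whether a different group at this place, such as an amine or a carboxylic acid on the phenyl ring, would move the number beyond the scatter in either direction.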